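This account rests on a few compounds, and the source may have more. Where it says the series, first, only, none or still open, it means among the compounds named here.

In a functional assay for inhibition of sodium/hydrogen exchanger (Oryctolagus cuniculus) (on this read-out higher numbers stand for weaker inhibition and lower numbers for stronger inhibition), compound 1 `Cc1cc(C)c(S(C)(=O)=O)cc1C(=O)N=C(N)N` gives 11 nM, compound 2 `CCOc1cc(C)c(C(=O)N=C(N)N)cc1S(C)(=O)=O` gives 19 nM, and compound 3 `Cc1cc(OC(C)(C)C)c(S(C)(=O)=O)cc1C(=O)N=C(N)N` gives 9.4 nM. For the measured compounds named here, compound 3 thus holds the lowest of the three numbers, although its gap to compound 1 lies within the scatter, as the step of a 1.2-fold lower number from compound 1 to compound 3 (0.07 log units; within the scatter) shows; only the step of a 2.0-fold lower number from compound 2 to compound 3 (0.31 log units; beyond the scatter) goes beyond it, and that modestly. The step of a 1.7-fold higher number from compound 1 to compound 2 (0.24 log units; within the scatter) likewise stays within the scatter.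

Compound 4 `Cc1cc(Oc2cncc(Cl)c2)c(S(C)(=O)=O)cc1C(=O)N=C(N)N` differs from compound 3 in one place: 5-chloropyridin-3-yl in place of tert-butyl on an oxygen on an aromatic ring. The measured step that bears on this change is the one at the same oxygen, a 2.0-fold lower number from compound 2 to compound 3 (0.31 log units; beyond the scatter), where tert-butyl replaced ethyl; the step of a 1.2-fold lower number from compound 1 to compound 3 (0.07 log units; within the scatter), where tert-butoxy replaced methyl on the aromatic carbon, is also relevant and is small. Going by the values given here, both suggest that what sits on this oxygen moves this assay little, yet none of the measured steps put an aromatic ring there, so the entering 5-chloropyridin-3-yl reaches outside the measured ground. A step of no more than modest size, in either direction, is therefore expected, and the estimate is set near compound 3 with a wide range. The expected step is a 1.3-fold higher number from compound 3 to compound 4 (0.11 log units; within the scatter). Compound 4 is expected to give 12 nM, between 4 nM and 40 nM.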

Compound 4, half-maximal inhibitory concentration: 14 nM
Compound 4: the middle estimate sits 1.2-fold (0.07 log units) below what was measured, within the range that was stated.
By their numbers in this assay, from the lowest: compounds 3, 1, 4 and 2 (each within the scatter of the next, the first and the last beyond it).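

In this assay, an aromatic ring on this oxygen leaves the read-out where the smaller groups had it: 5-chloropyridin-3-yl in place of tert-butyl gives a 1.5-fold higher number from compound 3 to compound 4 (0.17 log units; within the scatter), 5-chloropyridin-3-yl in place of ethyl gives a 1.4-fold lower number from compound 2 to compound 4 (0.13 log units; within the scatter), and (5-chloropyridin-3-yl)oxy in place of methyl on the aromatic carbon gives a 1.3-fold higher number from compound 1 to compound 4 (0.10 log units; within the scatter). The earlier compounds shown here had only methyl, ethoxy and tert-butoxy at this place, so compound 4 extends the measured ground to a six-membered aromatic ring carrying a ring nitrogen and a chlorine, and none of its three steps goes beyond the scatter. Nothing at hand accounts for how little this change moves the number.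

The compounds shown leave open whether the ring nitrogen or the chlorine of the 5-chloropyridin-3-yl group matters at all, a question that a plain phenyl or an unsubstituted pyridin-3-yl on this oxygen would address. Also open, going by these compounds, is how this assay would respond to an amine or a carboxylic acid on this aromatic carbon, in place of the methyl and the ethers seen so far.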